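Estimating Half-life After One Change at the Carbonyl

A few compounds are considered here, and "the series" means these few. Any claim that something is new, unique, unknown or untested is made for them only; others in the source may bear on it.

Among the compounds with values here, in an in vivo ADME assay on the whole organism (strain Han Wistar) for metabolic stability, with Rattus norvegicus as the target (on this read-out lower numbers stand for a shorter-lived compound and higher numbers for a longer-lived compound), compound 1 `CCCC[C@H](NC(=O)O[C@@H]1C(=O)N(C(=O)c2ccno2)CC1(C)C)C(=O)C(=O)N[C@H](C)c1ccccc1` gives 0.6 h, the lowest of the three numbers so far. Compound 2 `CCCC[C@H](NC(=O)O[C@@H]1C(=O)N(S(=O)(=O)c2ccccc2)CC1(C)C)C(=O)C(=O)N[C@H](C)c1ccccc1` gives 2.5 h, and compound 3 `CCCC[C@H](NC(=O)O[C@@H]1C(=O)N(C(=O)c2nc3ccccc3s2)CC1(C)C)C(=O)C(=O)Nc1cc[nH]n1` gives 3 h. The new compound 4 `CCCC[C@H](NC(=O)O[C@@H]1C(=O)N(C(=O)Nc2c(C)noc2C)CC1(C)C)C(=O)C(=O)N[C@H](C)c1ccccc1` differs from compound 1 in one place: (3,5-dimethyl-1,2-oxazol-4-yl)amino in place of 1,2-oxazol-5-yl on a carbonyl carbon. Within the data shown here, only one measured step touches the same part of the shared core: a 4.2-fold higher number from compound 1 to compound 2 (0.62 log units; beyond the scatter), a swap of the group carried by that amide-type nitrogen in a ring. Among the measured compounds shown here, compound 3 differs from compound 1 in two places, so its value shows only that another group there can go with a longer half-life. For compound 4 a modest lengthening is therefore expected, roughly a 2.5-fold higher number from compound 1 to compound 4 (0.40 log units; beyond the scatter). Compound 4 is estimated at 1.5 h, between 0.6 h and 3.5 h.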

Compound 4, half-life in the Rattus norvegicus assay: 0.583 h
Estimate against measurement, compound 4: 2.6-fold (0.41 log units) above, and the stated range ends above it.
By their numbers in the Rattus norvegicus assay, from the lowest: compounds 4 and 1 (each within the scatter of the next); then compounds 2 and 3 (each within the scatter of the next).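

In the Rattus norvegicus assay, this swap on a carbonyl carbon gives a 1.0-fold lower number from compound 1 to compound 4 (0.01 log units; within the scatter), so the new group does not separate the two compounds on half-life. In the Rattus norvegicus assay, the sulfonyl-bearing compound stands apart, with a 4.3-fold lower number from compound 2 to compound 4 (0.63 log units; beyond the scatter), so the group on this amide-type nitrogen can matter, but this carbamoyl does not lengthen half-life. In a physicochemical assay for solubility, in simulated intestinal fluid, at pH 6.8 (on this read-out lower numbers stand for lower solubility and higher numbers for higher solubility), compound 1 gives 68 ug/mL and compound 4 gives 320 ug/mL, so the change pays off in solubility without a half-life cost: the measured solubility of compound 1, 68 ug/mL, and of compound 4, 320 ug/mL, a 4.7-fold higher number (0.67 log units; beyond the scatter)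

Still open, on these data alone, is whether a simple amine or a morpholine on this carbonyl carbon would keep that solubility and also lengthen half-life.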